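This account rests on a few compounds, and the source may have more. Where it says the series, first, only, none or still open, it means among the compounds named here.

Going by the values given here, compound 1 `N#Cc1cnc(NCc2cnccc2C(F)(F)F)cc1NC[C@H]1CC[C@@H](O)CC1` is the only compound here with an actual number in an assay on isolated protein for inhibition of protein kinase C delta type (Homo sapiens), read by TR-FRET, with a stated time of 2 h (a higher number here means a weaker inhibitor, a lower number a stronger inhibitor), where compound 1 gives 500 nM. Compound 2 `N#Cc1cnc(NCc2ccccc2C(F)(F)F)cc1N[C@H]1C[C@H](C(N)=O)C1` gives only a limit in this assay, namely > 10000 nM, which is the limit of > 10000 nM in this assay, at which 1 of the 2 values shown sits. Compound 3 `N#Cc1cnc(NCc2cnccc2C(F)(F)F)cc1N[C@H]1CC[C@@H](C(N)=O)CC1` differs from compound 1 by 4-carbamoylcyclohexyl in place of (4-hydroxycyclohexyl)methyl on a nitrogen on an aromatic ring. Among the compounds with values here, no measured pair here shows this change alone, so the direction must be guessed; the move from compound 1 to compound 3 is expected to weaken binding by a 4.0-fold higher number from compound 1 to compound 3 (0.60 log units; beyond the scatter). Compound 3 is therefore estimated at 2000 nM in this assay, with a likely range from 500 nM to 10000 nM.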

Compound 3, half-maximal inhibitory concentration: 400 nM
For compound 3 the middle estimate is 5.0-fold (0.70 log units) above the measured one, outside the stated range (below it).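

Placing 4-carbamoylcyclohexyl where (4-hydroxycyclohexyl)methyl stood gives a 1.3-fold lower number from compound 1 to compound 3 (0.10 log units; within the scatter) in this assay, so on this nitrogen the two groups cannot be told apart in this assay. The step to a different group at this position therefore need not cost binding, at least on the core of compound 1. Nothing shown gives a reason for this match.

From the compounds shown here alone, it remains open whether a carboxylic acid or an amine in place of the carbamoyl group would keep this level of binding. A longer chain between the nitrogen and the cyclohexane ring also remains untested among the compounds shown.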